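A few compounds are considered here, and "the series" means these few. Any claim that something is new, unique, unknown or untested is made for them only; others in the source may bear on it.

Compound 1 `CN(C[C@H]1Cc2c(cccc2N2C[C@@H]3C[C@H]2CN3)CN1)[C@H]1CCCc2cccnc21`: > 30000 nM
Compound 2 `c1cnc2c(c1)CCC[C@@H]2N(CC1CCCCC1)C[C@H]1Cc2c(cccc2N2CCNCC2)CN1`: > 30000 nM

In a functional assay on CCRF-CEM cells for agonist activity at C-X-C chemokine receptor type 4 (Homo sapiens), read by calcium flux, with a stated time of 25 min (a higher number here means that more compound is needed for the effect, a lower number that less compound is needed), compound 1 gives > 30000 nM, which is a limit of the assay and not a number. Compound 2 in this assay likewise stands at a limit, > 30000 nM. Among the compounds with values here, both values shown sit at the limit of > 30000 nM in this assay, at which 2 of the 2 values shown sit, so compound 1 cannot be placed above or below compound 2 on these numbers, and no measured pair differs in one place, so no measured step is available.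

Compound 3 `CN(C[C@H]1Cc2c(cccc2N2C[C@H]3C[C@@H]2CN3)CN1)[C@H]1CCCc2cccnc21` has not yet been measured in this assay. Compared with compound 1, (the two compounds have the same atoms and bonds and differ only in configuration as drawn: 2 of 4 stereo elements differ; a stereocentre at a saturated ring carbon is drawn S in compound 1 and R in compound 3; a stereocentre at a saturated ring carbon is drawn S in compound 1 and R in compound 3). Within the data shown here, since compound 1 sits at the limit of > 30000 nM in this assay, at which 2 of the 2 values shown sit, the two measured compounds give no measured step from which the size of a change in configuration could be read. The step of an at least 1.2-fold lower number from compound 1 to compound 3 (0.07 log units; that floor lies within the scatter) is expected, which lies within the scatter. Compound 3 is thus expected most likely to remain at the limit of the assay, though a change in configuration could in principle move it. Compound 3 is estimated at 25000 nM, within 3000 nM to 100000 nM.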

Compound 3, half-maximal effective concentration: > 30000 nM
Compound 3 was reported as a limit; the forecaster's own chance of this, stated with the estimate: 70%; middle value at least 1.2-fold (0.07 log units) away from the limit.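

In this assay compound 3 gives > 30000 nM, which is a limit of the assay and not a number. Compound 1 also stands at a limit, so no step between compound 1 and compound 3 can be read: the limit of > 30000 nM in this assay, at which 3 of the 3 values shown sit.

The compounds shown leave open whether a change in configuration affects the response in this assay at all, and how large any such effect would be.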